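This account rests on a few compounds, and the source may have more. Where it says the series, first, only, none or still open, it means among the compounds named here.

Among the compounds with values here, compound 2, with the structure `Cc1cc2nn(-c3ccccc3)c(N)c2c(=O)[nH]1`, is one of two compounds measured in an assay on isolated protein for inhibition of MAP kinase-activated protein kinase 2 (Homo sapiens), read by mobility shift assay, tested at 30 uM; a lower number here means less inhibition, a higher number more inhibition at the concentration tested (going by the name of the read-out). In this assay compound 2 gives -4%. Within the data shown here, the only other measured compound, compound 1, has the structure `Cc1cc2[nH]nc(N)c2c(N2CCCCC2)n1`; in this assay compound 1 gives -1%. The two numbers lie within the usual scatter of each other, so nothing separates compound 1 from compound 2 on this read-out: both sit close to zero inhibition at the concentration tested. Among the measured compounds shown here, no step between measured compounds is available to show how any structural change moves the read-out.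

Compound 3, with the structure `CC(C)(C)c1cc2nn(-c3ccccc3)c(N)c2c(=O)[nH]1`, is not yet measured. It differs from compound 2 in one place: tert-butyl in place of methyl on an aromatic carbon. For the measured compounds named here, with no measured step to draw on, and both measured compounds near zero, the expectation is that the change from compound 2 to compound 3 produces no step beyond the scatter, that is, a step of about a number 2 percentage points higher from compound 2 to compound 3 (within the scatter). Compound 3 is therefore estimated to give about -2% in this assay, with a likely range from -12% to 10%.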

Compound 3, a percentage reported as inhibition, at one concentration (the size of the read-out at that concentration, not a potency): 6%
Estimate against measurement, compound 3: 8 percentage points below; low and high end bracket the measured number.
By their numbers in this assay, from the lowest: compounds 2, 1 and 3 (each within the scatter of the next).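

Within the data shown here, the first step comes from the aromatic carbon next to the ring nitrogen: in this assay, tert-butyl in place of methyl gives a number 10 percentage points higher from compound 2 to compound 3 (within the scatter). This position therefore carries 4 heavy atoms in place of 1 with no shift beyond the scatter, so enlarging this group from methyl to tert-butyl does not separate the two compounds on this read-out. Nothing measured here bears on what lies behind the small step, and this single pair offers no explanation of its size or direction.

On these data alone, it remains open whether a group of a different kind at this carbon, such as an amine, a carboxylic acid or a longer chain like n-hexyl, would move the read-out beyond the scatter, since methyl and tert-butyl are both plain carbon groups without hydrogen-bond donors or acceptors. Also open, as far as these compounds go, is whether a change elsewhere on the shared core of compound 2 and compound 3, such as a pyridine ring in place of the phenyl ring, would produce any clear inhibition at the concentration tested.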